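Methoxy in place of carboxy on compound 2

The source may hold more compounds than are shown below. What is called first, only, known or untested is meant among the compounds shown, and "the series" means these compounds.

Compound 1 `Cn1c(=O)c(S(=O)(=O)c2ccc(F)cc2F)cc2cnc(Nc3ccc4[nH]c(C(=O)O)cc4c3)nc21` gives 10000 nM
Compound 2 `Cn1c(=O)c(S(=O)(=O)c2ccc(C(=O)O)cc2)cc2cnc(Nc3ccc4[nH]ccc4c3)nc21` gives 10000 nM
Compound 3 `O=c1c(S(=O)(=O)c2ccc(F)cc2F)cc2cnc(Nc3ccc4[nH]ccc4c3)nc2n1C1CCCC1` gives 5000 nM

All three compounds were tested in a functional assay on DU-145 cells (Homo sapiens) for inhibition, read by trypan blue exclusion, with a stated time of 72 h (a higher number here means a weaker inhibitor, a lower number a stronger inhibitor), and are compared by their half-maximal inhibitory concentrations. Compound 2 stands level with compound 1, and compound 3 lies within the scatter of both, so the three values do not separate.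

Compound 4 `COc1ccc(S(=O)(=O)c2cc3cnc(Nc4ccc5[nH]ccc5c4)nc3n(C)c2=O)cc1` has not yet been measured. It differs from compound 2 by methoxy in place of carboxy on an aromatic carbon, para to a large group (methoxy in place of carboxy on an aromatic carbon). For the measured compounds named here, no measured pair isolates this change, so any forecast is weakly supported. Compound 1 and compound 2 both carry a carboxy group, while compound 3 carries none and gives 5000 nM in this assay despite differing from compound 4 elsewhere. A moderate step toward a lower number is therefore expected, although a result within the scatter would be unsurprising. The expected size is a 4.0-fold lower number from compound 2 to compound 4 (0.60 log units; beyond the scatter) (an estimate). In this assay compound 4 is expected at 2500 nM (estimated range 300 nM to 10000 nM).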

Compound 4, half-maximal inhibitory concentration: 500 nM
Compound 4: the middle estimate sits 5.0-fold (0.70 log units) above what was measured; measured number inside the range.
By their numbers in this assay, from the lowest: compound 4; then compounds 3, 1 and 2 (each within the scatter of the next).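

In this assay, replacing 4-carboxyphenyl with 4-methoxyphenyl gives a 20-fold lower number from compound 2 to compound 4 (1.30 log units; beyond the scatter) and is the only change shown that stands alone in one place. The earlier compounds shown here could not show this: no two of them differ in one place and their values do not separate, whereas this comparison shows that the group on this aromatic carbon, para to a large group, can shift the number well beyond the scatter. Nothing presented here bears on why the number falls.

The compounds shown leave open whether the step comes from adding methoxy or from losing carboxy. They also leave open how an amine, a hydroxy group or a longer chain such as ethoxy would read at this position.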